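Carbonyl substituent swap from compound 3 to compound 4

This account rests on a few compounds, and the source may have more. Where it says the series, first, only, none or still open, it means among the compounds named here.

Measured so far in a functional assay on PC-3 cells (Homo sapiens) for antiproliferative activity, read by MTT assay, with a stated time of 72 h; a higher number here means a weaker inhibitor, a lower number a stronger inhibitor:
- compound 1 `CCn1cc(C(CC)(CC)c2ccc(C#CC(O)(CC)CC)c(C)c2)cc1C(=O)NCCN(C)C` gives 10100 nM
- compound 2 `CCn1cc(C(CC)(CC)c2ccc(C#CC(O)(CC)CC)c(C)c2)cc1C(=O)NCCCN(C)C` gives 15100 nM
- compound 3 `CCn1cc(C(CC)(CC)c2ccc(C#CC(O)(CC)CC)c(C)c2)cc1C(=O)OCCO` gives 11400 nM

Compound 3 at 11400 nM cannot be separated from the other two compounds, and the three numbers form one tight group. Compound 4 `CCn1cc(C(CC)(CC)c2ccc(C#CC(O)(CC)CC)c(C)c2)cc1C(=O)NCC(=O)O` carries (carboxymethyl)amino in place of 2-hydroxyethoxy on a carbonyl carbon and otherwise matches compound 3. Two measured steps swap a group on that same carbonyl carbon and bear most directly on this change: a 1.1-fold higher number from compound 1 to compound 3 (0.05 log units; within the scatter) and a 1.3-fold lower number from compound 2 to compound 3 (0.12 log units; within the scatter) are both small. The remaining step of a 1.5-fold higher number from compound 1 to compound 2 (0.17 log units; within the scatter) is of similar size. No measured compound carries (carboxymethyl)amino, so this change lies outside what the series has tested, and the range is kept wide for that reason. No step beyond the scatter is expected in this assay for this swap. The estimated step is a 1.2-fold higher number from compound 3 to compound 4 (0.09 log units; within the scatter) and it is not expected to be resolved from repeat measurements. Compound 4 is estimated at 14000 nM with an expected range from 7000 nM to 30000 nM in this read-out.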

Compound 4, half-maximal inhibitory concentration: 6300 nM
For compound 4 the middle estimate is 2.2-fold (0.35 log units) above the measured one; measured number below the stated range.
By their numbers in this assay, from the lowest: compounds 4, 1, 3 and 2 (each within the scatter of the next, the first and the last beyond it).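

Among the compounds shown here, in the series read by this assay, the step of a 2.4-fold lower number from compound 2 to compound 4 (0.38 log units; beyond the scatter) is the first to lie beyond the scatter, though it remains modest, and it shows that a change at this carbonyl carbon can separate two compounds. The steps of a 1.8-fold lower number from compound 3 to compound 4 (0.26 log units; within the scatter) and a 1.6-fold lower number from compound 1 to compound 4 (0.20 log units; within the scatter) both stay within the scatter, so compound 4 separates only from compound 2, and the (carboxymethyl)amino group does not set itself apart from the 2-hydroxyethoxy group of compound 3 or the (2-(dimethylamino)ethyl)amino group of compound 1. Nothing measured here explains the step from compound 2.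

The compounds shown leave open whether a longer chain between the amide nitrogen and the carboxylic acid would keep compound 4 within the scatter of compound 1 and compound 3, or would move it further from compound 2. As far as these compounds go, it also remains open whether a methyl ester in place of the carboxylic acid, or a morpholine in place of the dimethylamino group, would produce a step of any greater size on this carbonyl carbon.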